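Triazolylmethyl spiro series on liver cells: limits throughout

The compounds below may be only part of what the source reports. "The series", "measured", "known", "first", "only" and "open" are said of these compounds alone.

Measured so far in an ADME assay on L02 cells (Homo sapiens) for antiproliferative activity, read by MTT assay, with a stated time of 48 h; a higher number here means a weaker inhibitor, a lower number a stronger inhibitor:
compound 1, `N#CC1=C(N)Oc2c(c3nc4ccccc4nc3c3ccccc23)C12C(=O)N(Cc1cnnn1-c1ccc(S(N)(=O)=O)cc1)c1ccccc12`: compound 1 gives > 50000 nM, a limit of the assay.
compound 2, `N#CC1=C(N)Oc2c(c3nc4ccccc4nc3c3ccccc23)C12C(=O)N(Cc1cnnn1-c1ccc(Cl)c(Cl)c1)c1ccccc12`: compound 2 gives > 50000 nM, a limit of the assay.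
compound 3, `Cc1ccccc1-n1nncc1CN1C(=O)C2(C(C#N)=C(N)Oc3c(N)cc4nc5ccccc5nc4c32)c2ccccc21`: compound 3 gives > 50000 nM, a limit of the assay.

Compound 3 therefore stands where every measured compound stands, at the limit of > 50000 nM in this assay, at which 3 of the 3 values shown sit; no number separates it from compound 1 or compound 2.

Compound 4 is `CC(=O)Nc1ccc(-n2nncc2CN2C(=O)C3(C(C#N)=C(N)Oc4c(N)cc5nc6ccccc6nc5c43)c3ccccc32)cc1`. It differs from compound 3 in one place: 4-acetamidophenyl in place of 2-methylphenyl on an aromatic nitrogen.

Among the compounds with values here, only one measured step touches a group on an aromatic nitrogen of the same five-membered ring, a step that the two limits leave unreadable from compound 1 to compound 2. Both ends of that step sit at the limit, so its size cannot be read, and it gives no measured size to carry over to the change from compound 3 to compound 4. With no readable step and all three values at the limit, a step beyond the scatter is not expected in this assay in either direction.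

Compound 4 is accordingly expected to give 80000 nM, with a range of 40000 nM to 200000 nM, most likely again as a limit. The expected step from compound 3 is a step that the limit leaves unreadable from compound 3 to compound 4, estimated as within the scatter.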

Compound 4, half-maximal inhibitory concentration: > 50000 nM
Compound 4: no number, only a limit; the forecaster's own chance of this, stated with the estimate: 85%; the middle value is on the limit's open side.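

In this assay compound 4 gives > 50000 nM, a limit and not a number. The step from compound 3 to compound 4 therefore cannot be read, and the series stays where it stood: the limit of > 50000 nM in this assay, at which 4 of the 4 values shown sit.

The compounds shown leave open how far any of them lies from that limit, and whether any group on the aromatic nitrogen brings a value off it.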